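Aryl variation on the cinnamate ester series, next step

The source may report more compounds than this note shows. Statements on the series, on what has been measured and on what is new or still open speak of the compounds shown alone.

Compounds 1, 2 and 3 share one core and differ only in the aryl group on the ester-side double bond. Compound 1 `COc1cc(OC)c(OC)cc1/C=C/COC(=O)/C=C/c1ccc(OC)c(OC)c1` gives 100% in a functional assay on the whole organism (strain Kunming) with Mus musculus as the target, with a stated time of 0.5 h, at a dose of 300 mg/kg by the intraperitoneal route; a lower number here means a stronger effect, a higher number a weaker effect of the compound at the dose given. Compound 2 `COc1cc(OC)c(OC)cc1/C=C/COC(=O)/C=C/c1ccccc1C(F)(F)F` gives 100% in this assay, and compound 3 `COc1cc(OC)c(OC)cc1/C=C/COC(=O)/C=C/c1cccc(Br)c1` gives 100%. The steps are no change at the digits printed from compound 1 to compound 2 (within the scatter), no change at the digits printed from compound 1 to compound 3 (within the scatter) and no change at the digits printed from compound 2 to compound 3 (within the scatter); compound 3 therefore sits level with compounds 1 and 2, and none of the three can be ordered against the others.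

Compound 4 `COc1cccc(/C=C/C(=O)OC/C=C/c2cc(OC)c(OC)cc2OC)c1` is not yet measured. It differs from compound 3 by methoxy in place of bromo on an aromatic carbon. The three measured steps all swap one aryl group for another at this same position, and each stays within the scatter, so the change to compound 4 is expected to give no change at the digits printed from compound 3 to compound 4 (within the scatter), with no shift beyond the scatter in either direction. Compound 4 is thus expected to give 100% in this assay, within a range from 85% to 100%; this rests on three compounds only.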

Compound 4, a percentage reported as activity, at one dose (the size of the read-out at that dose, not a potency): 100%
Beside the measured number, compound 4's estimate shows no gap at the digits printed; the range from low to high includes it.
By their numbers in this assay, from the lowest: compounds 1, 2, 3 and 4 (each within the scatter of the next).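

In this assay, methoxy in place of bromo at the same place on the ring gives no change at the digits printed from compound 3 to compound 4 (within the scatter), so the position now also tolerates a group carrying a hydrogen-bond acceptor without separating from the bromo compound. The same holds against the other aryl groups: the swap to 3-methoxyphenyl gives no change at the digits printed from compound 2 to compound 4 (within the scatter), and hydrogen in place of methoxy gives no change at the digits printed from compound 1 to compound 4 (within the scatter), so the number of methoxy groups on this ring does not separate compounds here either. No measurement at hand offers an explanation for this flat result.

Going by these compounds, all four compounds read the same, so it remains open whether any aryl group at this position can move the read-out in this assay. An amine or a carboxylic acid on this ring, or a longer chain between the ester and the ring, would test that.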